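This account rests on a few compounds, and the source may have more. Where it says the series, first, only, none or still open, it means among the compounds named here.

Working notes on the series.

Two cores are in hand. Compound 1 `C=C(CC)C(=O)c1ccc(OCc2nc(-c3ccc4ccccc4c3)cs2)c(C)c1C` and compound 2 `C=C(CC)C(=O)c1ccc(OCc2nc(-c3ccc(C(F)(F)F)cc3)cs2)c(C)c1C` share one; compound 3 `C=C(CC)C(=O)c1ccc(OCc2nc(-c3ccc4ccccc4c3)cs2)c(Cl)c1Cl` and compound 4 `C=C(CC)C(=O)c1ccc(OCc2nc(-c3ccc(C(F)(F)F)cc3)cs2)c(Cl)c1Cl` share the other. How the core of compound 1 and the core of compound 3 differ is not broken down here.

In an assay on HL-60 cells for inhibition of glutathione S-transferase P (Homo sapiens), read by spectrophotometry, tested at 5 uM (a higher number here means more inhibition at the concentration tested (going by the name of the read-out), a lower number less inhibition), compound 1 gives 0%, and compound 2 gives 0%. The step between them, no change at the digits printed from compound 1 to compound 2 (within the scatter), comes with the change (4-(trifluoromethyl)phenyl in place of naphthalen-2-yl on an aromatic carbon). Compound 3 gives 4.3% in this assay; its values against compound 1 and compound 2 lie within the scatter, so no order among the three is claimed.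

Compound 4 carries the same change relative to compound 3, (4-(trifluoromethyl)phenyl in place of naphthalen-2-yl on an aromatic carbon), at a place described in the same words as for compound 1 to compound 2. Since the measured instance of this change left the read-out where it was, the step from compound 3 to compound 4 is expected to be a number 2.3 percentage points lower from compound 3 to compound 4 (within the scatter), resting on no change at the digits printed from compound 1 to compound 2 (within the scatter) and on compound 3 at 4.3%. Compound 4 is therefore estimated at 2% in this assay, with the likely range running from -4% to 10%.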

Compound 4, a percentage reported as inhibition, at one concentration (the size of the read-out at that concentration, not a potency): 22.2%
Beside the measured number, compound 4's estimate is 20.2 percentage points below it; the measured number lies above the stated range.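

On the core of compound 3, the change to 4-(trifluoromethyl)phenyl in place of naphthalen-2-yl gives a number 17.9 percentage points higher from compound 3 to compound 4 (beyond the scatter) in this assay. The same change therefore does not carry over unchanged from the core of compound 1 to the core of compound 3, and its outcome in this series depends on the core that bears it: the same change on two cores in this assay, no change at the digits printed (within the scatter) from compound 1 to compound 2 and a number 17.9 percentage points higher (beyond the scatter) from compound 3 to compound 4, 17.9 percentage points apart, beyond the scatter of two such steps. This does not show what in the cores accounts for the difference or how the change would read on any further core, as each core offers a single pair, read at one concentration and giving no potency.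

Open, going by these compounds, is how other groups would read at the same aromatic carbon of the five-membered ring, for instance an amine or a carboxylic acid in place of naphthalen-2-yl or 4-(trifluoromethyl)phenyl. Also open, on these data alone, is whether a third core, for instance one carrying a nitrile, would follow compound 1 and compound 2 or compound 3 and compound 4.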